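Bromo to Methoxy on the Ketone Ring: An Expectation

The compounds below may be only part of what the source reports. "The series", "measured", "known", "first", "only" and "open" are said of these compounds alone.

Measured compounds:
compound 1, `O=C(/C=C/c1ccc(OCc2cn(Cc3ccccc3)nn2)cc1)c1ccc(Br)cc1`, 22%
compound 2, `O=C(/C=C/c1ccc(OCc2cn(Cc3ccc(F)cc3)nn2)cc1)c1ccc(Br)cc1`, 22%

In a functional assay on HepG2 cells (Homo sapiens) for inhibition, read by MTT assay, with a stated time of 48 h, tested at 10 uM (a higher number here means more inhibition of growth at the concentration tested, a lower number less inhibition of growth), compound 1 gives 22%. Compound 2, with fluoro in place of hydrogen on an aromatic carbon, gives 22% in this assay, and the step of no change at the digits printed from compound 1 to compound 2 (within the scatter) is the only measured one. Compound 1 thus stands level with compound 2. Compound 3, `COc1ccc(C(=O)/C=C/c2ccc(OCc3cn(Cc4ccccc4)nn3)cc2)cc1`, differs from compound 1 by methoxy in place of bromo on an aromatic carbon. No measured step touches this position or this kind of exchange, so nothing shown argues for a move in either direction. Compound 3 is therefore expected to give 22% (range 8% to 40%) in this assay. The estimated step of no change at the digits printed from compound 1 to compound 3 (within the scatter) is accordingly expected to lie within the scatter.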

Compound 3, percent growth inhibition at one concentration: 51%
The estimate for compound 3 lay 29 percentage points below the measured number; measured number above the stated range.
By their numbers in this assay, from the lowest: compounds 1 and 2 (each within the scatter of the next); then compound 3.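

Where the earlier pair showed only no change at the digits printed from compound 1 to compound 2 (within the scatter), the exchange of bromo for methoxy gives a number 29 percentage points higher from compound 1 to compound 3 (beyond the scatter) in this assay. Growth inhibition thus responds to the group at this aromatic carbon, a place the fluoro exchange did not touch. Nothing at hand explains the rise. Only bromo and methoxy are shown here, so whether the gain comes from adding methoxy or from losing bromo stays open; an amine, a hydroxy group or a longer ethoxy chain could separate the two. Going by these compounds, whether the exchange carries over to compound 2 also remains open.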